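Adding a fluoro group to compound 2

The compounds below may be only part of what the source reports. "The series", "measured", "known", "first", "only" and "open" are said of these compounds alone.

compound 1 `COc1ccc(OC)c(N2C(=O)CSC2c2cccc(C(=O)NCCCCc3ccccc3)c2)c1` gives > 1000 nM as a limit
compound 2 `O=C(NCCCCn1cccn1)c1cccc(C2SCC(=O)N2c2ccccn2)c1` gives 60.3 nM as a number
compound 3 `O=C(NCCCCc1ccccc1)c1cccc(C2SCC(=O)N2c2ccccn2)c1` gives 19.7 nM as a number

In a functional assay on HOS-TE85 cells (Homo sapiens) for inhibition, read by CCK-8 assay, with a stated time of 72 h (on this read-out lower numbers stand for stronger inhibition and higher numbers for weaker inhibition), compound 2 gives 60.3 nM and so holds the higher of the two actual numbers, with compound 3 the lower one. The value for compound 1 is only a limit. Compound 4 `O=C(NCCCCn1cccn1)c1cccc(C2SCC(=O)N2c2cc(F)ccn2)c1` has not been measured. It differs from compound 2 by one small change, (fluoro in place of hydrogen on an aromatic carbon), with fluoro in place of hydrogen on an aromatic carbon, so that pyridin-2-yl becomes 4-fluoropyridin-2-yl.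

Among the compounds with values here, two measured steps bear on this. The large one (an at least 50-fold lower number from compound 1 to compound 3 (1.70 log units; beyond the scatter)) replaced a whole group at the same place, so changes there can matter, but it rests on a limit. The modest one (a 3.1-fold lower number from compound 2 to compound 3 (0.49 log units; beyond the scatter)) lies on the chain instead. Neither tests a fluoro group, so in this assay a small step is expected, possibly none beyond the scatter, with no firm direction. The expected change is a 1.2-fold lower number from compound 2 to compound 4 (0.08 log units; within the scatter) as an estimate only. Compound 4 is expected at 50 nM (estimated range 15 nM to 170 nM) in this read-out.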

Compound 4, half-maximal inhibitory concentration: 33.2 nM
Compound 4: the middle estimate sits 1.5-fold (0.18 log units) above what was measured; measured number inside the range.
By their numbers in this assay, from the lowest: compounds 3, 4 and 2 (each within the scatter of the next, the first and the last beyond it). At a limit, above all of these: compound 1.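

In this assay, the change from pyridin-2-yl to 4-fluoropyridin-2-yl gives a 1.8-fold lower number from compound 2 to compound 4 (0.26 log units; within the scatter) and so shows that this aromatic carbon, opposite the ring nitrogen, takes a fluoro group with no change beyond the scatter. The earlier step at this place swapped a whole group and rested on a limit, whereas this one adds a single atom and keeps the rest of compound 2 unchanged. Nothing shown here gives a reason for this outcome.

On these data alone, whether the same fluoro group would behave alike on compound 3, which carries phenyl in place of 1H-pyrazol-1-yl, remains open. As far as these compounds go, it is also open how a chloro, methoxy, trifluoromethyl or amine group would fare at this same carbon.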